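The compounds below may be only part of what the source reports. "The series", "measured", "known", "first", "only" and "open" are said of these compounds alone.

Among the measured compounds shown here, in a functional assay on MDA-MB-231 cells (Homo sapiens) for antiproliferative activity, with a stated time of 48 h (on this read-out lower numbers stand for stronger inhibition and higher numbers for weaker inhibition), compound 3 `CCOC(=O)c1ccc(-c2ccc(N(CC)CC)nn2)cc1` gives 1500 nM, the lower of the two numbers measured so far. Compound 1 `CCN(CC)c1ccc(-c2ccc(C(C)=O)cc2)nn1` gives 5000 nM, which makes a 3.3-fold lower number from compound 1 to compound 3 (0.52 log units; beyond the scatter). Compound 2 `CCN(CC)c1ccc(-c2ccc(C(=O)O)cc2)nn1` is reported as a limit of the assay, > 25000 nM, and not as a number. Against that limit, the other two steps are an at least 5.0-fold higher number from compound 1 to compound 2 (0.69 log units; beyond the scatter) and an at least 16-fold lower number from compound 2 to compound 3 (1.22 log units; beyond the scatter).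

Compound 4 `CCOC(=O)c1ccc(-c2ccc(OCC)nn2)cc1` keeps the carbonyl side of compound 3 and changes the other side: ethoxy in place of diethylamino on an aromatic carbon, with ethoxy in place of diethylamino on an aromatic carbon. All three measured steps concern the group on the carbonyl, while diethylamino stays in place throughout. None of them therefore speaks directly to this change, and they serve only as a gauge of how far one substitution can move this assay, from modest to large. The direction rests on weak ground: compound 3, at 1500 nM, already holds the lowest number, so a modest move upward seems more likely than a further fall. The expected change is a 2.3-fold higher number from compound 3 to compound 4 (0.37 log units; beyond the scatter), though this is a loose estimate. For compound 4 the estimated value is 3500 nM, with an expected range from 800 nM to 15000 nM.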

Compound 4, half-maximal inhibitory concentration: > 25000 nM
Compound 4: only a limit was reported (the forecaster's own chance of this, stated with the estimate: 10%); middle value at least 7.1-fold (0.85 log units) away from the limit.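

In this assay compound 4 is reported only as a limit of the assay, > 25000 nM, and not as a number. Ethoxy in place of diethylamino on an aromatic carbon gives an at least 16-fold higher number from compound 3 to compound 4 (1.22 log units; beyond the scatter), so the group at this position, which stayed diethylamino through compounds 1, 2 and 3, moves the read-out further than the carbonyl change that gave a 3.3-fold lower number from compound 1 to compound 3 (0.52 log units; beyond the scatter). From the compounds shown here alone, this step marks only the smallest possible change, and the true size of the change stays unknown: the limit of > 25000 nM in this assay, at which 2 of the 4 values shown sit.

The compounds shown do not separate the exchange of the attached nitrogen for oxygen from the loss of heavy atoms in going from diethylamino to ethoxy, and a smaller amine such as dimethylamino, a ring amine such as pyrrolidine or a longer alkoxy chain at this position would bear on that question. They also leave open whether ethoxy would give the same result with a different group on the carbonyl, such as the methyl ketone of compound 1 or an amide.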